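The source may report more compounds than this note shows. Statements on the series, on what has been measured and on what is new or still open speak of the compounds shown alone.

Values measured in a toxicity assay on MRC5 cells (Homo sapiens) for inhibition, read by MTT assay, with a stated time of 72 h; on this read-out higher numbers stand for weaker inhibition and lower numbers for stronger inhibition:
- Compound 1 `CCCCCCCCCCCCC(=O)OCCc1ccc(O)c(O)c1`: 13200 nM
- Compound 2 `CCCCCCCCCCCCCCCC(=O)OCCc1ccc(O)c(O)c1`: > 50000 nM
- Compound 3 `CCCCCCCCCCC(=O)OCCc1ccc(O)c(O)c1`: > 50000 nM

Compound 1 is the only one of the three with a true number. Compound 2 reads > 50000 nM, which is a limit of the assay and not a number. Compound 3 reads > 50000 nM, which is also a limit. On these data alone, compound 3 therefore sits with compound 2 at the limit of > 50000 nM in this assay, at which 2 of the 3 values shown sit, so its real value is unknown.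

Compound 4 `CCCCCCCCCCCC(=O)OCCc1ccc(O)c(O)c1` extends the chain of compound 3 by one small change: methyl in place of hydrogen on a saturated chain carbon, ten or more bonds along the chain from a carbonyl carbon. The closest measured evidence is an at least 3.7-fold higher number from compound 1 to compound 3 (0.57 log units; beyond the scatter). Read backwards, this step shows that adding ethyl at the same place on compound 3 gives compound 1, the only compound with a measured number. Adding methyl is a smaller change of the same kind. Longer is not simply stronger, though, as an at least 3.7-fold higher number from compound 1 to compound 2 (0.57 log units; beyond the scatter) shows that compound 2 goes against such a trend. The step that the two limits leave unreadable from compound 2 to compound 3 adds nothing.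

A modest move to a lower number is therefore expected in this assay, although compound 4 may stay at the limit. For compound 4 the estimated value is 27000 nM, with an expected range from 11000 nM to 60000 nM. This estimate means an expected at least 1.8-fold lower number from compound 3 to compound 4 (0.26 log units; that floor lies within the scatter).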

Compound 4, half-maximal inhibitory concentration: 38100 nM
Compound 4: the middle estimate sits 1.4-fold (0.15 log units) below what was measured; measured number inside the range.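

With a second true number in this assay, the change can now be sized without relying on a limit: taking away this one methyl gives a 2.9-fold higher number from compound 1 to compound 4 (0.46 log units; beyond the scatter), so a single carbon on this saturated chain position can shift the reading by more than the usual scatter. Measured against the two compounds on either side, the picture is less firm, with an at least 1.3-fold lower number from compound 3 to compound 4 (0.11 log units; that floor lies within the scatter) and an at least 1.3-fold lower number from compound 2 to compound 4 (0.11 log units; that floor lies within the scatter), and neither floor on its own shows a real change. Compound 2 and compound 3 each carry a limit and not a number: the limit of > 50000 nM in this assay, at which 2 of the 4 values shown sit.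

The true values of compound 2 and compound 3 remain unknown, so the compounds shown cannot tell how sharply the reading changes with chain length on either side of compound 1, or whether compound 1 marks a true optimum. Also open, on these data alone, is what an amine or a carboxylic acid in place of methyl on this saturated chain carbon would do to the reading, since only plain hydrocarbon chains appear here.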